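The source may hold more compounds than are shown below. What is called first, only, known or untested is meant among the compounds shown, and "the series" means these compounds.

Of the compounds shown here, three sharing one core have been measured in a functional assay for inhibition, with Homo sapiens as the target; on this read-out higher numbers stand for weaker inhibition and lower numbers for stronger inhibition. Compound 1 (`O=C(O)COc1cccc(CCc2nc(-c3ccccc3)c(-c3ccccc3)o2)c1`) has hydrogen on the saturated chain carbon bound to an aromatic carbon and a saturated chain carbon, and gives 1200 nM. Compound 2 (`CCOC(=O)C(Cc1cccc(OCC(=O)O)c1)c1nc(-c2ccccc2)c(-c2ccccc2)o1`) has ethoxycarbonyl on that carbon and gives 120 nM. Compound 3 (`O=C(O)COc1cccc(CC(C(=O)O)c2nc(-c3ccccc3)c(-c3ccccc3)o2)c1`) has carboxy there and gives 14000 nM, the highest number of the three and so the weakest inhibition.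

Compound 4 (`CS(=O)(=O)C(Cc1cccc(OCC(=O)O)c1)c1nc(-c2ccccc2)c(-c2ccccc2)o1`) has not yet been measured. It carries methylsulfonyl in place of the carboxy of compound 3: methylsulfonyl in place of carboxy on a saturated chain carbon bound to an aromatic carbon and a saturated chain carbon.

For the measured compounds named here, no measured compound carries methylsulfonyl, so the guidance is indirect. Adding ethoxycarbonyl gave a 10-fold lower number from compound 1 to compound 2 (1.00 log units; beyond the scatter), whereas adding carboxy gave a 12-fold higher number from compound 1 to compound 3 (1.07 log units; beyond the scatter). Exchanging the ethyl for hydrogen gave a 120-fold higher number from compound 2 to compound 3 (2.07 log units; beyond the scatter). Among these three compounds, only the carboxy compound lies above compound 1, so leaving carboxy is expected to lower the number in this assay by a large step, and the result should fall nearer compound 2 and compound 1 than compound 3. The expected size of this change is a 40-fold lower number from compound 3 to compound 4 (1.60 log units; beyond the scatter). For compound 4 the estimated value is 350 nM, with an expected range from 70 nM to 1800 nM.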

Compound 4, half-maximal inhibitory concentration: 7960 nM
Estimate against measurement, compound 4: 23-fold (1.36 log units) below; the whole stated range lies below it.
By their numbers in this assay, from the lowest: compound 2; then compound 1; then compounds 4 and 3 (each within the scatter of the next).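

In this assay, methylsulfonyl in place of carboxy on the saturated chain carbon leaves the two compounds indistinguishable (a 1.8-fold lower number from compound 3 to compound 4 (0.25 log units; within the scatter)), even though methylsulfonyl has 0 hydrogen-bond donors against 1 for carboxy, so leaving carboxy does not by itself give a low number at this carbon. Methylsulfonyl also stands on the higher side of hydrogen (a 6.6-fold higher number from compound 1 to compound 4 (0.82 log units; beyond the scatter)) and far from ethoxycarbonyl (a 66-fold higher number from compound 2 to compound 4 (1.82 log units; beyond the scatter)), which makes ethoxycarbonyl the only one of the four groups at this carbon with a number lower than that of hydrogen, while carboxy and methylsulfonyl both have higher ones. Nothing available accounts for this difference between the groups.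

From the compounds shown here alone, it remains open whether the lower number is peculiar to ethoxycarbonyl or is shared by other groups on this carbon, such as methoxycarbonyl, a longer ester chain, a primary amide or a nitrile. Going by these compounds, it is also open whether a small alkyl group such as methyl would stay near hydrogen or move with the larger groups.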